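Adding a chlorine to the quinazoline part: compound 4 expected

The source may report more compounds than this note shows. Statements on the series, on what has been measured and on what is new or still open speak of the compounds shown alone.

Measured so far:
compound 1 `Cc1cccc(COc2ccc(/C=C/C(/C=C/c3ccccn3)=N/Oc3ncnc4cccc(C)c34)cc2)c1` gives 97%
compound 2 `Clc1ccc(COc2ccc(/C=C/C(/C=C/c3ccccn3)=N/Oc3ncnc4cc(Cl)ccc34)cc2)cc1` gives 88.1%
compound 3 `Cc1cccc(COc2ccc(/C=C/C(/C=C/c3ccccn3)=N/Oc3ncnc4ccccc34)cc2)c1` gives 97.5%

These three compounds share one core and differ only in small groups on two aromatic rings. The read-out is a functional assay on SMMC-7721 cells (Homo sapiens) for inhibition, read by MTT assay, with a stated time of 72 h, tested at 10 uM; a lower number here means a weaker effect, a higher number a stronger effect of the compound at the concentration tested. Among the compounds with values here, compound 3 stands close to the other two: the one measured step, a number 0.5 percentage points higher from compound 1 to compound 3 (within the scatter), is within the scatter, and the number for compound 2 lies within the scatter of compound 3 as well. Within the data shown here, compound 2 differs from compound 1 in two places, so its two values show only that both compounds act strongly.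

The step now in question leads from compound 3 to compound 4 `Cc1cccc(COc2ccc(/C=C/C(/C=C/c3ccccn3)=N/Oc3ncnc4cc(Cl)ccc34)cc2)c1`. The change is chloro in place of hydrogen on an aromatic carbon. Among the measured compounds shown here, no measured step isolates this change: the only chloro on this ring appears in compound 2, together with a second change elsewhere. What the numbers do show is that all three measured compounds sit near full inhibition in this assay, with every gap within the scatter. The expected step of a number 3.5 percentage points lower from compound 3 to compound 4 (within the scatter) is therefore none beyond the scatter, and the estimate for compound 4 is 94%, with a range from 85% to 99%.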

Compound 4, a percentage reported as inhibition, at one concentration (the size of the read-out at that concentration, not a potency): 95.6%
Beside the measured number, compound 4's estimate is 1.6 percentage points below it; measured number inside the range.
By their numbers in this assay, from the lowest: compounds 2, 4, 1 and 3 (each within the scatter of the next).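

In this assay, within the data shown here, the step of a number 1.9 percentage points lower from compound 3 to compound 4 (within the scatter) is the first to isolate chloro in place of hydrogen on this ring, the change from quinazolin-4-yl to 7-chloroquinazolin-4-yl, and it shows that this aromatic carbon can carry a chlorine with no change beyond the scatter. Compound 4 also links the series in two single-place comparisons: 3-methylphenyl in place of 4-chlorophenyl gives the step of a number 7.5 percentage points higher from compound 2 to compound 4 (within the scatter), and 7-chloroquinazolin-4-yl in place of 5-methylquinazolin-4-yl gives the step of a number 1.4 percentage points lower from compound 1 to compound 4 (within the scatter), so neither swap separates these compounds at the one concentration tested. No measurement shown here accounts for how closely these values sit together.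

The compounds shown leave open whether this carbon would keep the inhibition with something other than chlorine, such as an amine, a carboxylic acid or a longer chain. They also leave open whether chloro and hydrogen differ in potency, since a percentage at a single concentration is not a potency and could hide a difference that a full concentration series might reveal.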